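Amino for methyl at the assay limit

The source may hold more compounds than are shown below. What is called first, only, known or untested is meant among the compounds shown, and "the series" means these compounds.

- Compound 1 `Cc1nnc(-c2nc(C3CCCCC3)n(-c3cccc(Cl)c3F)c2-c2ccc(F)c(Cl)c2)o1` reads > 30000 nM, a limit
- Compound 2 `O=C(O)c1nc(-c2ccccc2)n(-c2cccc(Cl)c2F)c1-c1ccc(F)c(Cl)c1` reads > 30000 nM, a limit
- Compound 3 `Cc1ccc(Cl)cc1-n1c(-c2ccccc2)nc(C(=O)O)c1-c1cccc(Cl)c1` reads > 30000 nM, a limit

These readings come from a functional assay on SAOS-2 cells (Homo sapiens) for antiproliferative activity, read by fluorescence, with a stated time of 72 h; a lower number here means a stronger inhibitor, a higher number a weaker inhibitor. A reading with a sign in front of it is a limit of the assay and not a measured number. Compound 1 stands at such a limit, so no exact potency is known for it. The same holds across the set, which shows (the limit of > 30000 nM in this assay, at which 3 of the 3 values shown sit).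

Compound 4 `Nc1nnc(-c2nc(C3CCCCC3)n(-c3cccc(Cl)c3F)c2-c2ccc(F)c(Cl)c2)o1` differs from compound 1 in one place: amino in place of methyl on an aromatic carbon. The 5-methyl-1,3,4-oxadiazol-2-yl group becomes 5-amino-1,3,4-oxadiazol-2-yl, with amino in place of methyl on an aromatic carbon of a five-membered aromatic ring with 2 nitrogen and 1 oxygen.

Going by the values given here, no pair of measured compounds shows how large a step this kind of swap gives. In this assay, no step beyond the scatter is expected in either direction, and another limit reading is the likeliest result. That expectation rests only on (the limit of > 30000 nM in this assay, at which 3 of the 3 values shown sit). The expected change is a number no higher from compound 1 to compound 4 (the limit leaves the size open). For compound 4 the estimated half-maximal inhibitory concentration is 30000 nM, with an expected range of 10000 nM to 60000 nM.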

Compound 4, half-maximal inhibitory concentration: > 30000 nM
Compound 4 was reported as a limit (the forecaster's own chance of this, stated with the estimate: 80%); the middle value sits exactly at the limit.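

Compound 1 and compound 4 both stand at a limit of the assay and not at a measured number, so the swap of methyl for amino gives no step that can be read: the limit of > 30000 nM in this assay, at which 4 of the 4 values shown sit.

The compounds shown leave open how strongly any of them inhibits, and whether amino and methyl at this place differ in potency at all.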